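This account rests on a few compounds, and the source may have more. Where it says the series, first, only, none or still open, it means among the compounds named here.

Working notes on the series. Compound 1 `Cc1cc(COc2ccccc2Cl)nc(-c2ccccn2)n1` gives 316 nM in a functional assay on cells for antagonist activity at Free fatty acid receptor 1 (Homo sapiens), read by TR-FRET and inositol phosphate accumulation, with a stated time of 2 h; on this read-out lower numbers stand for stronger inhibition and higher numbers for weaker inhibition; compound 2 `Cc1cc(COc2ccc(Cl)cc2)nc(-c2ccccn2)n1` gives 251 nM; compound 3 `Cc1cc(COc2cccc(F)c2)nc(-c2ccccn2)n1` gives 794 nM, the highest of the three numbers. The steps of a 2.5-fold higher number from compound 1 to compound 3 (0.40 log units; beyond the scatter) and a 3.2-fold higher number from compound 2 to compound 3 (0.50 log units; beyond the scatter) both change the aryl ether, while a 1.3-fold lower number from compound 1 to compound 2 (0.10 log units; within the scatter) stays within the scatter. Compound 4 `CN(C)c1cc(COc2cccc(F)c2)nc(-c2ccccn2)n1` differs from compound 3 by dimethylamino in place of methyl on an aromatic carbon. Among the measured compounds shown here, none of the measured steps touches this position; all three vary the phenyl ether only, so none bears directly on the change. For the measured compounds named here, with no measured precedent, a step beyond the scatter is not expected in this assay in either direction. Compound 4 is therefore estimated at 800 nM, with a range from 300 nM to 2000 nM. The expected step is a 1.0-fold higher number from compound 3 to compound 4 (0.00 log units; within the scatter).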

Compound 4, half-maximal inhibitory concentration: 1580 nM
The estimate for compound 4 lay 2.0-fold (0.30 log units) below the measured number; measured number inside the range.
By their numbers in this assay, from the lowest: compounds 2 and 1 (each within the scatter of the next); then compounds 3 and 4 (each within the scatter of the next).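

In this assay, among the compounds shown here, the change at this aromatic carbon next to the ring nitrogen gives a 2.0-fold higher number from compound 3 to compound 4 (0.30 log units; within the scatter) and so gives the first reading at a position that the phenyl ether steps left untouched. With the 3-fluorophenyl ether of compound 3, dimethylamino is tolerated in place of methyl, with the step staying within the scatter. Nothing measured here accounts for the step. Still open, from the compounds shown here alone, is how a morpholine or a hydroxyl group on this carbon would read. Also open, going by these compounds, is whether the same change holds with the 4-chlorophenyl ether of compound 2.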